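Aminothiazole Guanidine Series: Bromo to Fluoro Exchange

A few compounds are considered here, and "the series" means these few. Any claim that something is new, unique, unknown or untested is made for them only; others in the source may bear on it.

Measured compounds:
- Compound 1, `Cc1nc(N)sc1CCCN/C(N)=N/C(=O)NCC(C)CCc1ccccc1`: 63.1 nM
- Compound 2, `Cc1nc(N)sc1CCCN/C(N)=N/C(=O)NC(C)c1ccc(Br)cc1`: 30.2 nM
- Compound 3, `Cc1nc(N)sc1CCCN/C(N)=N/C(=O)NCc1ccccc1`: 69.2 nM

In an assay on membranes from Sf9 cells for displacement of a labelled ligand from histamine H2 receptor (Homo sapiens), read by scintillation counting, with a stated time of 60 min (a higher number here means a weaker inhibitor, a lower number a stronger inhibitor), compound 2 gives 30.2 nM, the lowest of the three numbers. Compound 1 sits higher at 63.1 nM, and compound 3 higher still at 69.2 nM; both gaps to compound 2 lie beyond the usual scatter, so compound 2 is the strongest inhibitor of the three on these data.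

Compound 4, `Cc1nc(N)sc1CCCN/C(N)=N/C(=O)NC(C)c1ccc(F)cc1`, has not yet been measured in this assay. It differs from compound 2 in one place: fluoro in place of bromo on an aromatic carbon. The shared core and the side chain bearing the ring are unchanged.

For the measured compounds named here, no step between measured compounds covers a halogen exchange of this kind, so the expectation rests on compound 2 alone. A modest move toward a weaker number is expected for the step from compound 2 to compound 4, a 1.8-fold higher number from compound 2 to compound 4 (0.26 log units; within the scatter), though a result within the scatter of compound 2 would not surprise. For compound 4 the estimate in this assay is 55 nM, with a range of 25 nM to 120 nM.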

Compound 4, inhibition constant: 31.6 nM
Beside the measured number, compound 4's estimate is 1.7-fold (0.24 log units) above it; measured number inside the range.
By their numbers in this assay, from the lowest: compounds 2, 4, 1 and 3 (each within the scatter of the next, the first and the last beyond it).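

In this assay the exchange of 4-bromophenyl for 4-fluorophenyl gives a 1.0-fold higher number from compound 2 to compound 4 (0.02 log units; within the scatter) and so leaves the reading unchanged within the scatter. For the compounds shown here, this is the first step that can be read at a single place: on this aromatic carbon, para to a large group, bromo and fluoro cannot be told apart in this assay. No measurement on hand explains why the two halogens read alike.

From the compounds shown here alone, whether that holds beyond the halogens stays open: a methoxy group, an amine or a carboxylic acid at the same place could read differently. Also open, going by these compounds, is the contribution of the methyl group on the carbon bearing the ring, as compound 3 differs from compound 2 in more than one place.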